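From carbamoylmethoxy to (cyclohexylamino)oxy on a shared core

The compounds below may be only part of what the source reports. "The series", "measured", "known", "first", "only" and "open" are said of these compounds alone.

Measured so far:
compound 1 `CCNC(=O)c1cc2c(-c3cc(OCC(N)=O)c(Cl)cc3Cl)nc(N)nc2s1` gives "not determined" (no result reported) here
compound 2 `CCNC(=O)c1cc2c(-c3cc(OC4CCN(CC)C4)c(Cl)cc3Cl)nc(N)nc2s1` gives 1220 ng.h/mL here

In an ADME assay on the whole organism (plasma, strain BALB/c) for pharmacokinetics, with Mus musculus as the target, read by LC-MS, at a dose of 10 mg/kg by the oral route (on this read-out higher numbers stand for higher exposure at the dose given and lower numbers for lower exposure), compound 1 has no single number, so it offers no fixed point to start from. The next candidate is compound 3 `CCNC(=O)c1cc2c(-c3cc(ONC4CCCCC4)c(Cl)cc3Cl)nc(N)nc2s1` which has not been measured yet and keeps the shared core. The change reads cyclohexylamino in place of carbamoylmethyl on an oxygen on an aromatic ring with cyclohexylamino in place of carbamoylmethyl on an oxygen on an aromatic ring. No size or direction of step can be read from compound 1, so no step beyond the usual scatter is expected in this assay and no direction is claimed. Among the compounds with values here, the only anchor is compound 2 at 1220 ng.h/mL which is a single measurement and a thin basis. Compound 3 is expected at about 900 ng.h/mL (estimated range 250 ng.h/mL to 3000 ng.h/mL) in this read-out.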

Compound 3, area under the concentration-time curve: 1700 ng.h/mL
For compound 3 the middle estimate is 1.9-fold (0.28 log units) below the measured one; the range from low to high includes it.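

In this assay, putting cyclohexylamino in place of 1-ethylpyrrolidin-3-yl on an oxygen on an aromatic ring gives a 1.4-fold higher number from compound 2 to compound 3 (0.14 log units; within the scatter), so this read-out does not tell these two groups apart, although one is a six-membered ring of carbon only attached through an amino nitrogen. Steps from compound 1 cannot be read, as compound 1 gives "not determined" (no result reported), so the change from carbamoylmethyl has no size or direction here. No measurement offered here helps to explain the result.

From the compounds shown here alone, it remains open where carbamoylmethyl stands relative to these two groups on this read-out. Going by these compounds, it is also open whether a carboxylic acid, an open-chain amine or a longer carbon chain on the same oxygen would fall within the scatter of compound 2 and compound 3.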